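The source may hold more compounds than are shown below. What is called first, only, known or untested is meant among the compounds shown, and "the series" means these compounds.

Compound 1, `CCOC(=O)/C=C/[C@H]1C[C@@H](O)[C@@H](O)C1`: in an ADME assay on S2 cells (Drosophila melanogaster) for cytotoxicity, read by MTT assay (on this read-out lower numbers stand for an effect already at smaller amounts and higher numbers for an effect only at larger amounts of compound), compound 1 gives > 350000 nM, which is a limit of the assay and not a number.
Compound 2, `NC(=O)/C=C/[C@H]1C[C@@H](O)[C@@H](O)C1`: in this assay compound 2 gives > 250000 nM, again a limit of the assay.
Compound 3, `CCCCNC(=O)/C=C/[C@H]1C[C@@H](O)[C@@H](O)C1`: in this assay compound 3 gives > 250000 nM, also a limit of the assay.

The account follows the step from compound 3 to compound 4, `O=C(/C=C/[C@H]1C[C@@H](O)[C@@H](O)C1)NO`. Compound 3 stands at the limit of > 250000 nM in this assay, at which 2 of the 3 values shown sit, while the remaining value sits at the limit of > 350000 nM in this assay, at which 1 of the 3 values shown sits. For the measured compounds named here, none of the measured steps can be read: a step that the two limits leave unreadable from compound 1 to compound 2, a step that the two limits leave unreadable from compound 1 to compound 3 and a step that the two limits leave unreadable from compound 2 to compound 3 are all left unreadable by the two limits. The change from compound 3 to compound 4 is hydroxy in place of butyl on an amide-type nitrogen. The step that touches the same amide-type nitrogen is a step that the two limits leave unreadable from compound 2 to compound 3, and its size is not readable either. Therefore no step beyond the scatter is expected in this assay, and compound 4 is expected to remain at a limit. For compound 4 the expected value in this assay is estimated at 250000 nM, with a range from 100000 nM to 500000 nM. The expected step from compound 3 to compound 4 is a number no higher from compound 3 to compound 4 (the limit leaves the size open).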

Compound 4, half-maximal effective concentration: > 250000 nM
Compound 4: a limit, no number; the forecaster's own chance of this, stated with the estimate: 85%; the middle value sits exactly at the limit.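

In this assay compound 4 gives > 250000 nM, again a limit of the assay and not a number, so its steps from compound 1, compound 2 and compound 3 cannot be read. The compounds shown leave open whether any change on the carbonyl carbon shifts the read-out in this assay at all.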